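The source may report more compounds than this note shows. Statements on the series, on what has been measured and on what is new or still open speak of the compounds shown alone.

Compound 2 `Cc1nc(-c2ccccc2)sc1C(=O)CSc1nc(-c2ccccc2)c(C#N)c(=O)[nH]1` and compound 1 `Cc1nc(-c2ccc(Cl)cc2)sc1C(=O)CSc1nc(-c2ccccc2)c(C#N)c(=O)[nH]1` share one core and differ only where chloro has been replaced by hydrogen. In a functional assay on U-87MG ATCC cells for antiproliferative activity against U-87 MG (Homo sapiens), read by MTT assay, with a stated time of 48 h, tested at 100 uM (a lower number here means a stronger effect, a higher number a weaker effect of the compound at the concentration tested), compound 1 gives 11.4% and compound 2 gives 9.23%, the lower of the two numbers, though the step of a number 2.2 percentage points lower from compound 1 to compound 2 (within the scatter) lies within the scatter. Compound 3 `COc1ccc(-c2nc(C)c(C(=O)CSc3nc(-c4ccccc4)c(C#N)c(=O)[nH]3)s2)cc1` differs from compound 2 by methoxy in place of hydrogen on an aromatic carbon. Among the measured compounds shown here, the only step that bears on this change sits on the same ring and was small, so no step beyond the scatter is expected, a number 0.8 percentage points higher from compound 2 to compound 3 (within the scatter). Compound 3 is therefore estimated to give 10%, between 2% and 22%, in this assay.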

Compound 3, a percentage reported as activity, at one concentration (the size of the read-out at that concentration, not a potency): 10.9%
The estimate for compound 3 lay 0.9 percentage points below the measured number; measured number inside the range.
By their numbers in this assay, from the lowest: compounds 2, 3 and 1 (each within the scatter of the next).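

With methoxy, this position on the aromatic ring, para to a large group, now carries a third kind of substituent, and in this assay the steps of a number 1.7 percentage points higher from compound 2 to compound 3 (within the scatter) and a number 0.5 percentage points lower from compound 1 to compound 3 (within the scatter) both stay within the scatter. Hydrogen, chloro and methoxy therefore cannot be told apart here at this single concentration. Nothing available explains this lack of separation.

Going by these compounds, whether an amine or a carboxylic acid at this position would also leave the read-out unchanged remains open. So does the effect of any change elsewhere on the shared core.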